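Swapping a halophenyl group on a sulfur-linked chain

The source may report more compounds than this note shows. Statements on the series, on what has been measured and on what is new or still open speak of the compounds shown alone.

Measured so far:
- compound 1, `COc1cc(-c2nnc(SCc3ccccc3F)o2)ccc1O`: 5790 nM
- compound 2, `COc1cc(-c2nnc(SCc3ccc(Cl)cc3)o2)ccc1O`: 11100 nM

Both numbers come from a functional assay on cells (T-cell, Mus musculus, strain BALB/c) for inhibition, read by MTT assay, with stated times of 24 h and 72 h; a higher number here means a weaker inhibitor, a lower number a stronger inhibitor. Among the measured compounds shown here, compound 2 has the highest of the two numbers, and its nearest neighbour is compound 1; the only step between them, a 1.9-fold higher number from compound 1 to compound 2 (0.28 log units; within the scatter), is within the scatter, so the two cannot be ordered.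

Compound 3, `COc1cc(-c2nnc(SCc3ccccc3Br)o2)ccc1O`, is not yet measured. It differs from compound 2 in one place: 2-bromophenyl in place of 4-chlorophenyl on a saturated chain carbon bound to a sulfur. For the measured compounds named here, the single step so far, from compound 1 to compound 2, changed the halophenyl group at this same place and moved the number only within the scatter, so a change of the halophenyl group here has not yet produced a clear shift. On that basis compound 3 is expected to land near both measured numbers, with no step beyond the scatter: a 1.5-fold lower number from compound 2 to compound 3 (0.17 log units; within the scatter). The estimate for compound 3 in this assay is 7500 nM, ranging from 3000 nM to 18000 nM.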

Compound 3, half-maximal inhibitory concentration: 17800 nM
Compound 3: middle estimate off by 2.4-fold (0.38 log units), on the low side; the measured number falls inside the stated range.
By their numbers in this assay, from the lowest: compounds 1, 2 and 3 (each within the scatter of the next, the first and the last beyond it).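

In this assay the halophenyl group on a saturated chain carbon bound to a sulfur now gives its first change beyond the scatter: bromo in place of fluoro on an aromatic carbon gives a 3.1-fold higher number from compound 1 to compound 3 (0.49 log units; beyond the scatter) and this step is modest. Among the compounds shown here, the halogen at this place can therefore move the number, although only this one pair shows it, while 2-bromophenyl in place of 4-chlorophenyl gives a 1.6-fold higher number from compound 2 to compound 3 (0.21 log units; within the scatter) and so leaves those two compounds unordered. No data shown here explain the shift.

A 4-bromophenyl group would help show whether the halogen alone or also its place on the ring matters. As far as these compounds go, it also remains open how a non-halogen group such as an amine on the ring, or a longer chain on the sulfur, would read here.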